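Changing the Ring on the Sulfur of Compound 2

The compounds below may be only part of what the source reports. "The series", "measured", "known", "first", "only" and "open" are said of these compounds alone.

Of the compounds shown here, two from a shared core have been tested in a functional assay on DU-145 cells (Homo sapiens) for antiproliferative activity, read by fluorescence and propidium iodide staining, with a stated time of 96 h; a lower number here means a stronger inhibitor, a higher number a weaker inhibitor. Compound 1 `CC(O)(CSc1cc(C(F)(F)F)cc(C(F)(F)F)c1)C(=O)Nc1ccc(C(F)(F)F)cc1` gives 16400 nM in this assay. Compound 2 `CC(O)(CSc1cccc(C(F)(F)F)c1)C(=O)Nc1cc(C(F)(F)F)cc(C(F)(F)F)c1` gives 10000 nM, the lower of the two numbers, yet the value of compound 1 lies within the usual scatter of it, so the two cannot be ranked against each other. Compound 3 `CC(O)(CSc1ccccc1OC(F)(F)F)C(=O)Nc1cc(C(F)(F)F)cc(C(F)(F)F)c1` has not yet been measured. It differs from compound 2 in one place: 2-(trifluoromethoxy)phenyl in place of 3-(trifluoromethyl)phenyl on a sulfur. Going by the values given here, no measured pair in this set shows what such a change does, so the expectation rests only on the fact that both measured compounds sit at weak and similar values in this assay. The step of a 1.2-fold higher number from compound 2 to compound 3 (0.08 log units; within the scatter) is expected to stay within the scatter, with no clear direction. Compound 3 is therefore estimated at 12000 nM in this assay, within a range from 4000 nM to 36000 nM.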

Compound 3, half-maximal inhibitory concentration: 6410 nM
The estimate for compound 3 lay 1.9-fold (0.27 log units) above the measured number, and the stated range covers the measured number.
By their numbers in this assay, from the lowest: compounds 3, 2 and 1 (each within the scatter of the next, the first and the last beyond it).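

Going by these compounds alone, this is the first step in the set that changes only the group on the sulfur: in this assay, putting 2-(trifluoromethoxy)phenyl in place of 3-(trifluoromethyl)phenyl gives a 1.6-fold lower number from compound 2 to compound 3 (0.19 log units; within the scatter) on the shared core. The position therefore takes a group with one more heavy atom and one hydrogen-bond acceptor, and the result cannot be told apart from that of compound 2. No measurement here explains why the two groups read alike.

Going by these compounds, whether an amine or a carboxylic acid on this ring, or a longer chain in place of the ring, would move the number beyond the scatter remains open. Also open, on these data alone, is whether 2-(trifluoromethoxy)phenyl would read the same on the other amide ring found in compound 1.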